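A few compounds are considered here, and "the series" means these few. Any claim that something is new, unique, unknown or untested is made for them only; others in the source may bear on it.

Of the compounds shown here, three that share one core have so far been tested in a functional assay on A549 cells (Homo sapiens) for cytotoxicity, read by MTT assay, with a stated time of 72 h; on this read-out higher numbers stand for weaker inhibition and lower numbers for stronger inhibition. Compound 1 `O=C(Nc1ccc(Oc2ccnc3[nH]ccc23)cc1)c1nn(-c2ccc(Br)cc2)ccc1=O` gives 6240 nM in this assay. Compound 2 `Cn1ccc2c(Oc3ccc(NC(=O)c4nn(-c5ccc(Br)cc5)ccc4=O)cc3)ccnc21` gives 59400 nM in this assay. Within the data shown here, the one single-point step measured between them, a 9.5-fold higher number from compound 1 to compound 2 (0.98 log units; beyond the scatter), is the only change whose effect is known. Compound 3 `Cc1cc(=O)n(-c2ccc(F)cc2)nc1C(=O)Nc1ccc(Oc2ncnc3[nH]ccc23)cc1` reaches only the limit of this assay, > 60000 nM, so for it no number exists. Compound 3 is one of the values sitting at the limit of > 60000 nM in this assay, at which 1 of the 3 values shown sits, and on the numbers shown it stands at the weak end, past where compound 1 and compound 2 were read.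

Compound 4 `Cc1cc(=O)n(-c2cccc(C(F)(F)F)c2)nc1C(=O)Nc1ccc(Oc2ncnc3[nH]ccc23)cc1` differs from compound 3 in one place: 3-(trifluoromethyl)phenyl in place of 4-fluorophenyl on an aromatic nitrogen. Among the measured compounds shown here, the only measured step concerns a methyl on an aromatic nitrogen and does not touch the 4-fluorophenyl, so no measured step bears on this change, and its size cannot be judged from the data. Since compound 3 already sits at the limit of this assay with > 60000 nM, the estimate for compound 4 is constrained mainly by that limit. Compound 4 is therefore expected to give about 60000 nM, within a range from 20000 nM to 150000 nM, and most likely again only a limit. The expected step of a number no higher from compound 3 to compound 4 (the limit leaves the size open) is thus estimated as no move beyond the scatter.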

Compound 4, half-maximal inhibitory concentration: 7570 nM
Compound 4: the middle estimate sits 7.9-fold (0.90 log units) above what was measured, and the stated range ends above it.
By their numbers in this assay, from the lowest: compounds 1 and 4 (each within the scatter of the next); then compound 2. At a limit, above all of these: compound 3.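

The aromatic group on the ring nitrogen is not a silent position: in this assay, this single change gives an at least 7.9-fold lower number from compound 3 to compound 4 (0.89 log units; beyond the scatter), lifting the series off the limit and onto a readable number. Among these compounds, the one earlier step concerned a methyl on a different aromatic nitrogen, so this is the first measured sign that the group at this position can by itself shift the cytotoxicity read-out. On these data alone, the true size of the step remains unknown because the starting value is a limit rather than a number: the limit of > 60000 nM in this assay, at which 1 of the 4 values shown sits.

The change replaces the fluorine with a trifluoromethyl and also moves the substituent to a different place on the phenyl ring, so the compounds shown cannot separate the effect of the group from the effect of its place. As far as these compounds go, it also remains open how a phenyl ring carrying a methoxy group, an amine or a carboxylic acid would read at this position, and whether the same change would have a similar effect on the core of compound 1.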